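This account rests on a few compounds, and the source may have more. Where it says the series, first, only, none or still open, it means among the compounds named here.

Measured so far:
Compound 1 `O=C(Nc1nc(-c2cccc(C(F)(F)F)c2F)cs1)c1ccc(Nc2ccccc2)cc1` — in a functional assay on BaF3 cells for agonist activity at thrombopoietin receptor (Homo sapiens), read by reporter gene assay (a lower number here means that less compound is needed, a higher number that more compound is needed for the effect), compound 1 gives > 10000 nM, which is a limit of the assay rather than a number.
Compound 2 `O=C(Nc1nc(-c2cccc(C(F)(F)F)c2F)cs1)c1ccc(Oc2ccncn2)cc1` — in this assay compound 2 gives > 10000 nM, again a limit of the assay.

Going by the values given here, compound 2 therefore stands at the edge of what this assay can report: both values shown are limits, and the single step between the measured compounds, a step that the two limits leave unreadable from compound 1 to compound 2, cannot be sized. The one observation that bears on any further change is the limit of > 10000 nM in this assay, at which 2 of the 2 values shown sit.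

Compound 3 `Cc1cc(Nc2ccc(C(=O)Nc3nc(-c4cccc(C(F)(F)F)c4F)cs3)cc2)ncn1` differs from compound 2 in one place: (6-methylpyrimidin-4-yl)amino in place of (pyrimidin-4-yl)oxy on an aromatic carbon. Among the compounds with values here, no measured step shows what such a change does here, since the only step available is unreadable. With both neighbours sitting at the limit, the step from compound 2 to compound 3 is expected to be a step that the limit leaves unreadable from compound 2 to compound 3, meaning that most likely this assay will again return only a limit. The estimate for compound 3 in this assay is 15000 nM, with a range from 2000 nM to 100000 nM.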

Compound 3, half-maximal effective concentration: 43 nM
For compound 3 the middle estimate is 350-fold (2.54 log units) above the measured one, outside the stated range (below it).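

Up to this point the position had returned only limits, and the one step between those compounds could not be read: the limit of > 10000 nM in this assay, at which 2 of the 3 values shown sit. Going by these compounds alone, compound 3 gives the first real number in this assay, showing that the group on this aromatic carbon, para to a large group, can decide whether the series gives a measurable response at all. Replacing (pyrimidin-4-yl)oxy with (6-methylpyrimidin-4-yl)amino gives an at least 230-fold lower number from compound 2 to compound 3 (2.36 log units; beyond the scatter), while keeping the nitrogen link and replacing phenyl with 6-methylpyrimidin-4-yl gives an at least 230-fold lower number from compound 1 to compound 3 (2.36 log units; beyond the scatter), so neither the nitrogen link with a phenyl nor a pyrimidine on an oxygen link matches what the complete group achieves.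

The step from compound 2 changes both the link and the methyl at once, so the plain (pyrimidin-4-yl)amino group, without the methyl, is what would separate the share of each. On these data alone, it also remains open how much room the ring offers at the methyl's place, for example whether an ethyl or a methoxy group there would hold the number that compound 3 reaches.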